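From cyclopropylmethyl to 4-fluorobenzyl on the shared core

The source may hold more compounds than are shown below. What is called first, only, known or untested is meant among the compounds shown, and "the series" means these compounds.

Measured in a functional assay on A549 cells (Homo sapiens) for antiproliferative activity, read by MTT assay, with a stated time of 48 h; on this read-out lower numbers stand for stronger inhibition and higher numbers for weaker inhibition:
Compound 1 `Cn1cc(-c2cnc3ccc(NC(=O)C4CC4)nc3c2)cn1`: > 50000 nM (a limit)
Compound 2 `CCNc1ccc2ncc(-c3cnn(C)c3)cc2n1`: > 50000 nM (a limit)
Compound 3 `Cn1cc(-c2cnc3ccc(NCC4CC4)nc3c2)cn1`: > 50000 nM (a limit)
Compound 4 `Cn1cc(-c2cnc3ccc(NCc4ccc(F)cc4)nc3c2)cn1`: not yet measured

Compound 3 gives only a limit in this assay, not a number. The whole series stands at the limit of > 50000 nM in this assay, at which 3 of the 3 values shown sit.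

Compound 4 carries 4-fluorophenyl in place of cyclopropyl on a saturated chain carbon bound to a nitrogen on an aromatic ring. The closest measured change is a step that the two limits leave unreadable from compound 2 to compound 3. The other two, a step that the two limits leave unreadable from compound 1 to compound 2 and a step that the two limits leave unreadable from compound 1 to compound 3, give no size either. Little change is therefore expected, with at best a modest move towards stronger inhibition. The expected step is an at least 1.2-fold lower number from compound 3 to compound 4 (0.09 log units; that floor lies within the scatter). For compound 4 the estimated value is 40000 nM, with an expected range of 10000 nM to 100000 nM.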

Compound 4, half-maximal inhibitory concentration: > 50000 nM
Compound 4 was reported as a limit; the forecaster's own chance of this, stated with the estimate: 60%; middle value at least 1.2-fold (0.09 log units) away from the limit.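

In this assay compound 4 gives > 50000 nM, a limit and not a number. Going by these compounds alone, no step from compound 1, compound 2 or compound 3 to compound 4 can be read. The compounds shown leave open whether any of these groups on the nitrogen changes the inhibition, as the whole series sits at one limit: the limit of > 50000 nM in this assay, at which 4 of the 4 values shown sit.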